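The compounds below may be only part of what the source reports. "The series", "measured", "known", "first", "only" and "open" are said of these compounds alone.

The shared core carries two side groups, and the compounds here differ in the chain attached through the nitrogen on the aromatic ring. Compound 1 `Cc1ccc2nc(N3CCCc4ccc(F)cc4C3)cc(NCC3(N)COC3)c2c1` bears a (3-aminooxetan-3-yl)methyl chain on that nitrogen. In an ADME assay on HEp-2 cells (Homo sapiens) for cytotoxicity, read by CCK-8 assay, with a stated time of 5 days (a higher number here means that more compound is tolerated, a lower number that less compound is tolerated), compound 1 reaches only a limit of the assay, > 100000 nM, so its true value is not known beyond that bound (the limit of > 100000 nM in this assay, at which 1 of the 2 values shown sits). Compound 2 `NCCCCNc1cc(N2CCc3ccccc3C2)nc2ccccc12` carries a different chain and a different second ring; in this assay compound 2 gives 7400 nM. Among the measured compounds shown here, no two measured compounds differ in just one place, so no measured step is available. Compound 3 `Cc1ccc2nc(N3CCCc4ccc(F)cc4C3)cc(NCCN3CCCCC3)c2c1` is compound 1 with one change: (piperidin-1-yl)methyl in place of 3-aminooxetan-3-yl on a saturated chain carbon bound to a nitrogen on an aromatic ring. For the measured compounds named here, with no measured step to lean on, the size of this change can only be guessed. Compound 3 is expected to be tolerated somewhat less than compound 1, a step of an at least 3.3-fold lower number from compound 1 to compound 3 (0.52 log units; beyond the scatter) beyond the scatter but uncertain because compound 1 shows only a limit (the limit of > 100000 nM in this assay, at which 1 of the 2 values shown sits). In this assay compound 3 is estimated at 30000 nM, within a range from 6000 nM to 100000 nM.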

Compound 3, half-maximal cytotoxic concentration: 22000 nM
Estimate against measurement, compound 3: 1.4-fold (0.13 log units) above; low and high end bracket the measured number.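

Among the compounds shown here, this is the first change at this position that can be read as a step: on a saturated chain carbon bound to a nitrogen on an aromatic ring, with the rest of the molecule unchanged, putting (piperidin-1-yl)methyl in place of 3-aminooxetan-3-yl gives an at least 4.5-fold lower number from compound 1 to compound 3 (0.65 log units; beyond the scatter) in this assay. The group at this place therefore matters for how much compound is tolerated, and compound 3 with its 2-(piperidin-1-yl)ethyl chain falls within the measurable range at 22000 nM. The step has no known upper size, because compound 1 stands at a limit of the assay and not at a number: the limit of > 100000 nM in this assay, at which 1 of the 3 values shown sits.

The change swaps the ring, removes the amine carried on the oxetane and lengthens the chain all at once, and the compounds shown do not tell which of these carries the step. From the compounds shown here alone, how a morpholine ring or a dimethylamino group on the same ethyl chain, or a piperidine ring on a longer propyl chain, would stand in this assay remains open.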